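Benzimidazole amide in place of furopyridine: an expected loss

This account rests on a few compounds, and the source may have more. Where it says the series, first, only, none or still open, it means among the compounds named here.

Compound 3 `O=C(NCc1ccc(S(=O)(=O)N2CCCCC2)cc1)c1cc2cnccc2o1` stands second highest of three numbers in an assay for inhibition of Nicotinamide phosphoribosyltransferase (Homo sapiens), read by mass spectrometry, with stated times of 15 min and 30 min (on this read-out higher numbers stand for weaker inhibition and lower numbers for stronger inhibition), giving 140 nM. Compound 2 `O=C(NCc1ccc(S(=O)(=O)N2CCCCC2)cc1)c1cc2ccncc2o1` gives 40 nM, with a 3.5-fold higher number from compound 2 to compound 3 (0.54 log units; beyond the scatter) beyond the scatter, while compound 1 `O=C(NCc1ccc(S(=O)(=O)N2CCCCC2)cc1)c1cc2ccncc2[nH]1` gives 1000 nM. Compound 4 `O=C(NCc1ccc(S(=O)(=O)N2CCCCC2)cc1)c1ccc2nc[nH]c2c1` differs from compound 3 by a group of 9 heavy atoms (7 carbon, 2 nitrogen; one five-membered aromatic ring with 2 hetero atoms, one six-membered aromatic ring of carbon only) in place of a group of 9 heavy atoms (7 carbon, 1 nitrogen, 1 oxygen; one five-membered aromatic ring with 1 hetero atom, one six-membered aromatic ring with 1 hetero atom), on a carbonyl carbon. The measured step nearest to this runs the opposite way: a 7.1-fold lower number from compound 1 to compound 3 (0.85 log units; beyond the scatter) replaced a group of 7 carbon and 2 nitrogen with one of 7 carbon, 1 nitrogen and 1 oxygen, and a 25-fold lower number from compound 1 to compound 2 (1.40 log units; beyond the scatter) pointed the same way. Reversing that kind of change is therefore expected to raise the number, though no measured pair isolates the loss of the six-membered ring hetero atom. Compound 4 is expected to give 600 nM, with a range from 150 nM to 2500 nM. The expected step is a 4.3-fold higher number from compound 3 to compound 4 (0.63 log units; beyond the scatter).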

Compound 4, half-maximal inhibitory concentration: 310 nM
Compound 4: the middle estimate sits 1.9-fold (0.29 log units) above what was measured, within the range that was stated.
By their numbers in this assay, from the lowest: compound 2; then compound 3; then compound 4; then compound 1.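

The 1H-benzimidazol-6-yl group does not fall to the level of compound 1 on this carbonyl carbon: there is a 3.2-fold lower number from compound 1 to compound 4 (0.51 log units; beyond the scatter), but also a 2.2-fold higher number from compound 3 to compound 4 (0.35 log units; beyond the scatter) and a 7.8-fold higher number from compound 2 to compound 4 (0.89 log units; beyond the scatter). The two groups of 7 carbon and 2 nitrogen are therefore not equivalent at this place, so the count of heavy atoms alone does not set the number.

Nothing available explains these differences. Also open, on these data alone, is how an amine or a methoxy group on the six-membered ring of the 1H-benzimidazol-6-yl group would move the number.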